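This account rests on a few compounds, and the source may have more. Where it says the series, first, only, none or still open, it means among the compounds named here.

In an ADME assay for permeability, using PAMPA, at pH 7.4 (a higher number here means that the compound crosses the layer faster, a lower number that the compound crosses the layer more slowly), compound 2, `CN(C[C@H]1Cc2c(cccc2N2CCN(C3CC3)CC2)CN1)[C@H]1CCCc2cccnc21`, gives 265 nm/s, the highest of the three numbers measured, with compound 3, `c1cnc2c(c1)CCC[C@@H]2N(CC1CC1)C[C@H]1Cc2c(cccc2N2CCNCC2)CN1`, at 87 nm/s and compound 1, `CCCN(C[C@H]1Cc2c(cccc2N2CCNCC2)CN1)[C@H]1CCCc2cccnc21`, at 26.5 nm/s. Compound 4, `C[C@@H]1CN(c2cccc3c2C[C@H](CN(C)[C@H]2CCCc4cccnc42)NC3)C[C@H](C)N1`, differs from compound 2 in one place: 3,5-dimethylpiperazin-1-yl in place of 4-cyclopropylpiperazin-1-yl on an aromatic carbon. Among the compounds with values here, no measured step touches that position; the only step within the set, a 3.3-fold higher number from compound 1 to compound 3 (0.52 log units; beyond the scatter), changes a group elsewhere. Compounds 1 and 3, which carry a piperazine bearing a hydrogen-bond donor, both sit below compound 2, so a drop is expected. The estimated step of a 3.5-fold lower number from compound 2 to compound 4 (0.55 log units; beyond the scatter) is therefore expected to be modest but beyond the scatter. Compound 4 is expected to reach about 75 nm/s, within a range of 30 nm/s to 170 nm/s.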

Compound 4, apparent permeability: 39 nm/s
Estimate against measurement, compound 4: 1.9-fold (0.28 log units) above, and the stated range covers the measured number.
By their numbers in this assay, from the lowest: compounds 1 and 4 (each within the scatter of the next); then compound 3; then compound 2.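

In this assay, within the data shown here, 3,5-dimethylpiperazin-1-yl in place of 4-cyclopropylpiperazin-1-yl on the aromatic carbon gives a 6.8-fold lower number from compound 2 to compound 4 (0.83 log units; beyond the scatter), the first measured step at this position. The change swaps a group with no hydrogen-bond donors for one with a hydrogen-bond donor and two defined stereocentres, and also removes the three-membered ring, so several features change in a single step. Nothing measured here gives a cause for this step. On these data alone, it remains open how a 4-methylpiperazin-1-yl or a morpholine group would behave at this position. As far as these compounds go, the separate contributions of the cyclopropyl and the two methyl groups also remain open.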